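Methyl next to the ring nitrogen on a thiosemicarbazone series

The source may hold more compounds than are shown below. What is called first, only, known or untested is meant among the compounds shown, and "the series" means these compounds.

Measured compounds in a functional assay on A-375 cells (Homo sapiens) for cytotoxicity, read by MTT assay, with a stated time of 72 h, tested at 10 uM; on this read-out higher numbers stand for more inhibition of growth at the one concentration tested and lower numbers for less inhibition of growth:
compound 1 `N/C(=N\NC(=S)N1CCCCCC1)c1ccccn1` gives 86.5%
compound 2 `Cc1ccnc(/C(N)=N/NC(=S)N2CCCCCC2)c1` gives 70.6%

Compound 1 stands highest of the two measured numbers in this assay; its nearest neighbour is compound 2, and the step of a number 15.9 percentage points lower from compound 1 to compound 2 (beyond the scatter) lies beyond the scatter, a modest drop brought about by a methyl in place of hydrogen on an aromatic carbon.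

Compound 3 `Cc1cccc(/C(N)=N/NC(=S)N2CCCCCC2)n1` has not yet been measured. It differs from compound 1 by methyl in place of hydrogen on an aromatic carbon. For the measured compounds named here, the only measured step that bears on this change is a number 15.9 percentage points lower from compound 1 to compound 2 (beyond the scatter), which places a methyl on the same six-membered ring, but not at the position used in compound 3. That step was a modest decrease beyond the scatter, so a decrease of similar size is the most defensible expectation, with wide uncertainty because the position of the methyl differs. Compound 3 is therefore expected to show a step of a number 14.5 percentage points lower from compound 1 to compound 3 (beyond the scatter) in this assay. The estimate for compound 3 is 72%, within a range from 55% to 88%.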

Compound 3, percent growth inhibition at one concentration: 79.9%
Beside the measured number, compound 3's estimate is 7.9 percentage points below it, and the stated range covers the measured number.
By their numbers in this assay, from the lowest: compounds 2, 3 and 1 (each within the scatter of the next, the first and the last beyond it).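

In this assay the methyl next to the ring nitrogen gives a number 6.6 percentage points lower from compound 1 to compound 3 (within the scatter), so at this position the change from hydrogen to methyl leaves the number within the scatter of the parent. The earlier pair showed the same kind of change with a number 15.9 percentage points lower from compound 1 to compound 2 (beyond the scatter), and compound 3 now shows that a step beyond the scatter does not follow from every methyl placed on this ring. Even so, compound 2 gives 70.6% and compound 3 gives 79.9%, two values within the scatter of each other, so the two methyl positions cannot be firmly separated, and no data given here account for the result.

The compounds shown leave open whether the place next to the ring nitrogen would tolerate anything other than methyl, such as an ethyl group, a methoxy group, a chlorine atom or an amine. They also leave open whether the picture seen at this one concentration would hold across a full range of concentrations.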